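The source may hold more compounds than are shown below. What is called first, only, known or untested is meant among the compounds shown, and "the series" means these compounds.

Four compounds built on two closely related cores are compared here in a functional assay on the whole organism with Mus musculus as the target, in the maximal electroshock model, with a stated time of 1 h; on this read-out lower numbers stand for an effect already at smaller amounts and higher numbers for an effect only at larger amounts of compound. Compound 1, with the structure `Cc1ccccc1-c1nnc(N(N)Cc2ccccc2)s1`, carries a methyl group on its phenyl ring and a benzyl group on the hydrazine side; in this assay compound 1 gives 27 mg/kg. Compound 2, with the structure `NN(Cc1ccccc1)c1nnc(-c2ccccc2Cl)s1`, differs from compound 1 only by one change, (chloro in place of methyl on an aromatic carbon), and in this assay compound 2 gives 186 mg/kg. That single change made a step of a 6.9-fold higher number from compound 1 to compound 2 (0.84 log units; beyond the scatter), so on this core the chloro analogue needs a clearly larger dose.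

Compound 3, with the structure `CNN(C)c1nnc(-c2ccccc2C)s1`, belongs to the other core, in which two methyl groups sit on the hydrazine instead of the benzyl group; the difference between the two cores is not broken down here. In this assay compound 3 gives 10 mg/kg, the lowest of the three measured numbers, with compound 1 nearest and compound 2 furthest.

Compound 4, with the structure `CNN(C)c1nnc(-c2ccccc2Cl)s1`, is not yet measured. It differs from compound 3 by chloro in place of methyl on an aromatic carbon. The surroundings are described a little differently, "ortho to a group of 9 heavy atoms" for compound 4 and "ortho to a large group" for compound 2, so this is the same kind of change rather than the same change. Within the data shown here, because the step of a 6.9-fold higher number from compound 1 to compound 2 (0.84 log units; beyond the scatter) was well beyond the scatter, a similar but somewhat tempered step, a 5.0-fold higher number from compound 3 to compound 4 (0.70 log units; beyond the scatter), is expected for compound 4, with no second example to show how reliably the change carries over. Compound 4 is therefore estimated at 50 mg/kg in this assay, expected to fall between 20 mg/kg and 150 mg/kg.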

Compound 4, dose for half-maximal effect: 43 mg/kg
Compound 4: the middle estimate sits 1.2-fold (0.07 log units) above what was measured, within the range that was stated.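

In this assay, chloro in place of methyl on an aromatic carbon gave a 4.3-fold higher number from compound 3 to compound 4 (0.63 log units; beyond the scatter), so the same swap pushed the number up on the core with two methyl groups on the hydrazine as well as on the core with the benzyl group. The two steps point the same way, and their sizes cannot be told apart given the normal spread of such measurements: the same change on two cores in this assay, a 6.9-fold higher number (0.84 log units; beyond the scatter) from compound 1 to compound 2 and a 4.3-fold higher number (0.63 log units; beyond the scatter) from compound 3 to compound 4, 1.6-fold (0.20 log units) apart, within the scatter of two such steps. This shows that, within these two pairs, the effect of the swap carried over from one core to the other, but two pairs are a small base, so it does not show that the swap would behave the same way on any further core, nor does it explain why the number rises.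

The compounds shown carry only methyl or chloro at this aromatic carbon, which leaves open what fluoro, methoxy or a plain hydrogen would do there. As far as these compounds go, it also remains open whether the step would hold with other groups on the hydrazine, such as an ethyl group or a longer chain, which would test the carry-over on a wider range of cores.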